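From phenyl to 3,4-dimethoxyphenyl on compound 3

A few compounds are considered here, and "the series" means these few. Any claim that something is new, unique, unknown or untested is made for them only; others in the source may bear on it.

Values in a functional assay on PC-3 cells (Homo sapiens) for inhibition, read by sulforhodamine B assay (a higher number here means a weaker inhibitor of growth, a lower number a stronger inhibitor of growth), follow
- Compound 1 `c1ccc(-c2ccc(-c3ccc(-c4nc5ccccc5[nH]4)cc3)cc2)cc1` gives 41200 nM
- Compound 2 `COc1cc(-c2ccc(-c3ccc(-c4nc5cc(C)ccc5[nH]4)cc3)cc2)cc(OC)c1OC` gives 180 nM
- Compound 3 `Oc1cccc2[nH]c(-c3ccc(-c4ccc(-c5ccccc5)cc4)cc3)nc12` gives 1240 nM

Compound 3 stands in the middle of these three numbers, lower than compound 1 and higher than compound 2. Compound 4 `COc1ccc(-c2ccc(-c3ccc(-c4nc5c(O)cccc5[nH]4)cc3)cc2)cc1OC` has 3,4-dimethoxyphenyl in place of phenyl, and the count runs 3,4-dimethoxyphenyl in place of phenyl on an aromatic carbon for this change. Going by the values given here, the one measured step, a 33-fold lower number from compound 1 to compound 3 (1.52 log units; beyond the scatter) and large, came from hydroxy in place of hydrogen on an aromatic carbon, and compound 4 keeps that hydroxy. Among the compounds with values here, no measured step covers the new swap. Within the data shown here, the only hint is compound 2, which also carries methoxy groups and gives 180 nM despite other differences. A moderate drop is therefore expected, and the expected step is a 3.5-fold lower number from compound 3 to compound 4 (0.55 log units; beyond the scatter) in this assay overall. Compound 4 is estimated at 350 nM with an expected range from 90 nM to 1400 nM in this reading.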

Compound 4, concentration for 50% growth inhibition: 1240 nM
Beside the measured number, compound 4's estimate is 3.5-fold (0.55 log units) below it; the measured number falls inside the stated range.
By their numbers in this assay, from the lowest: compound 2; then compounds 3 and 4 (each within the scatter of the next); then compound 1.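

In this assay, 3,4-dimethoxyphenyl in place of phenyl gives no change at the digits printed from compound 3 to compound 4 (within the scatter) and so leaves the growth-inhibition reading unmoved. The earlier compounds shown here could not show that this place, on an aromatic carbon para to a large group, accepts the two methoxy groups with no measurable gain or loss when the hydroxy is present. Nothing available explains this flat result.

From the compounds shown here alone, whether an amine or a carboxylic acid at this place would shift the number remains open. So does whether the same swap would also leave the number unmoved without the hydroxy, on compound 1.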